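The source may hold more compounds than are shown below. What is called first, only, known or untested is meant among the compounds shown, and "the series" means these compounds.

Of the compounds shown here, two of a shared core have been measured in a functional assay on RAW264.7 cells (Mus musculus) for inhibition, read by Griess assay, with stated times of 2 h and 24 h; a lower number here means a stronger inhibitor, a higher number a weaker inhibitor. Compound 1 `COc1ccc([C@@H]2CC(=O)c3c(O)cc(OCc4cn(C)nn4)cc3O2)cc1O` carries a (1-methyl-1H-1,2,3-triazol-4-yl)methyl group on the core; in this assay compound 1 gives 15200 nM, the highest of the two numbers. Compound 2 `COc1ccc([C@@H]2C/C(=N\O)c3c(O)cc(OCc4cn(C5CCCC5)nn4)cc3O2)cc1O` differs from compound 1 in more than one place, so its result can only be set alongside that of compound 1: in this assay compound 2 gives 6880 nM, a lower number, and the gap lies beyond the scatter of repeated measurements.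

Compound 3 `COc1ccc([C@@H]2CC(=O)c3c(O)cc(OCc4cn(CCCO)nn4)cc3O2)cc1O` is compound 1 with a single alteration, (2-hydroxyethyl in place of hydrogen on a saturated chain carbon bound to an aromatic nitrogen). Among the compounds with values here, no measured pair in this set shows a change of this kind on its own, so nothing here tells how such a change acts on the numbers. The alteration adds a short chain with one hydrogen-bond donor and one hydrogen-bond acceptor and leaves the rest of the structure untouched. The expected step from compound 1 to compound 3, a 1.3-fold lower number from compound 1 to compound 3 (0.10 log units; within the scatter), is therefore small, with no clear direction, and not beyond the scatter. For compound 3 the estimated value in this assay is 12000 nM, with a range from 5000 nM to 30000 nM.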

Compound 3, half-maximal inhibitory concentration: 16700 nM
Beside the measured number, compound 3's estimate is 1.4-fold (0.14 log units) below it; the range from low to high includes it.
By their numbers in this assay, from the lowest: compound 2; then compounds 1 and 3 (each within the scatter of the next).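

In this assay, exchanging the 1-methyl-1H-1,2,3-triazol-4-yl group for the 1-(3-hydroxypropyl)-1H-1,2,3-triazol-4-yl group gives a 1.1-fold higher number from compound 1 to compound 3 (0.04 log units; within the scatter). Within the data shown here, this is the first pair in the set that differs in one place only, and it gives the first direct reading of this position: a methyl and a 3-hydroxypropyl on the aromatic nitrogen cannot be told apart in this measurement, so adding 2-hydroxyethyl, with its hydrogen-bond donor and acceptor, brings no measurable gain or loss here. No measured information is available to explain this outcome.

Among these compounds, the single pair tests only one chain, so it remains open whether the same flat result would hold for a group of another kind at this place, such as a 3-aminopropyl group with its amine or a 2-carboxyethyl group with its carboxylic acid. It also leaves open whether a longer chain, such as 6-hydroxyhexyl, would read the same as the methyl of compound 1 or move the number beyond the scatter.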